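The source may hold more compounds than are shown below. What is called first, only, known or untested is meant among the compounds shown, and "the series" means these compounds.

In a functional assay (aorta) with Rattus norvegicus as the target (a lower number here means a stronger inhibitor, a higher number a weaker inhibitor), three compounds sharing one core have been measured. Compound 1 `CCOC(=O)CN(c1nc(C)cs1)[C@H]1c2cc(C#N)ccc2OC(C)(C)[C@@H]1O` gives 84000 nM. Compound 2 `CCOC(=O)CN(c1nc2ccccc2o1)[C@H]1c2cc(C#N)ccc2OC(C)(C)[C@@H]1O` reads > 30000 nM, which is a limit of the assay and not a number. Compound 3 `CCNC(=O)CN(c1ccccc1)[C@H]1c2cc(C#N)ccc2OC(C)(C)[C@@H]1O` reads > 30000 nM, which is also only a limit. Compound 3 therefore stands at the limit of > 30000 nM in this assay, at which 2 of the 3 values shown sit, with no number of its own.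

Compound 4 `CC1(C)Oc2ccc(C#N)cc2[C@H](N(Cc2ncc[nH]2)c2ccccc2)[C@H]1O` departs from compound 3 in one place: 1H-imidazol-2-yl in place of ethylcarbamoyl on a saturated chain carbon bound to a nitrogen on an aromatic ring. 1H-imidazol-2-yl takes the place of ethylcarbamoyl on a saturated chain carbon bound to a nitrogen on an aromatic ring, so that (ethylcarbamoyl)methyl becomes (1H-imidazol-2-yl)methyl.

Among the compounds with values here, only one measured step is available, a step that the limit leaves unreadable from compound 1 to compound 2. It concerns a different group, the one on the amine nitrogen, and so gives no guide to size or direction here. Within the data shown here, no measured step touches this side chain, and no shift beyond the usual scatter can be forecast from the data. The estimated change is a number no higher from compound 3 to compound 4 (the limit leaves the size open). Among the measured compounds shown here, with compound 1 at 84000 nM as the only true number, compound 4 is expected to stay weak in this assay. Another reading that is only a limit would not surprise for compound 4. For compound 4 the estimated value is 30000 nM, with an expected range from 8000 nM to 100000 nM.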

Compound 4, half-maximal inhibitory concentration: > 30000 nM
Compound 4 ended at the assay's limit; the forecaster's own chance of this, stated with the estimate: 60%; the middle value sits exactly at the limit.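

In this assay, compound 4 reads as a limit and not as a number, as does compound 3, so no step can be read from compound 3 to compound 4. Both stand at the same mark: the limit of > 30000 nM in this assay, at which 3 of the 4 values shown sit.

The compounds shown leave open whether 1H-imidazol-2-yl in place of ethylcarbamoyl on this side chain changes activity at all.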